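The source may hold more compounds than are shown below. What is called first, only, known or untested is meant among the compounds shown, and "the series" means these compounds.

Of the compounds shown here, three share one core and have been tested in a functional assay on A-375 cells (Homo sapiens) for antiproliferative activity, read by CCK-8 assay, with a stated time of 72 h, tested at 2 uM; on this read-out lower numbers stand for a weaker effect and higher numbers for a stronger effect at the one concentration tested. Compound 1 `Nc1ccccc1NC(=O)c1ccc(CSC(=S)N2CCN(C(c3ccccc3)c3ccccc3)CC2)cc1` gives 8.7% in this assay. Compound 2 `Nc1ccccc1NC(=O)c1ccc(CSC(=S)N2CCN(c3ccccc3)CC2)cc1` reaches 27.5% in this assay, and compound 3 `Nc1ccccc1NC(=O)c1ccc(CSC(=S)N2CCc3ccccc32)cc1` gives 25.7% in this assay. Among these three numbers compound 3 stands second highest; its value and that of compound 2 lie within the usual scatter of each other, while compound 1 sits lower by a margin beyond the scatter. Compound 4 `Nc1ccccc1NC(=O)c1ccc(CSC(=S)N2CCCc3ccccc32)cc1` has not yet been measured. It differs from compound 3 in one place: 1,2,3,4-tetrahydroquinolin-1-yl in place of 2,3-dihydro-1H-indol-1-yl on a thiocarbonyl carbon. Among the measured compounds shown here, no comparable step exists among the measured compounds, so the expected step in this assay is a number 0.7 percentage points lower from compound 3 to compound 4 (within the scatter), one that should stay within the scatter. Compound 4 is accordingly estimated at 25%, within 10% to 42%.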

Compound 4, a percentage reported as inhibition, at one concentration (the size of the read-out at that concentration, not a potency): 26.5%
Beside the measured number, compound 4's estimate is 1.5 percentage points below it; the range from low to high includes it.
By their numbers in this assay, from the lowest: compound 1; then compounds 3, 4 and 2 (each within the scatter of the next).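

In this assay, 1,2,3,4-tetrahydroquinolin-1-yl in place of 2,3-dihydro-1H-indol-1-yl on a thiocarbonyl carbon gives a number 0.8 percentage points higher from compound 3 to compound 4 (within the scatter). Among the compounds shown here, this is the first one-place comparison at this position, and the read-out at the one concentration tested does not tell the five-membered non-aromatic ring from the six-membered one. On these data alone, whether an amine or a carboxylic acid carried on the 1,2,3,4-tetrahydroquinolin-1-yl group would give a different number remains open. Nothing measured here speaks to what lies behind this small step.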